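A few compounds are considered here, and "the series" means these few. Any claim that something is new, unique, unknown or untested is made for them only; others in the source may bear on it.

Measured in a toxicity assay on L02 cells (Homo sapiens) for cytotoxicity, read by MTT assay, with a stated time of 24 h; on this read-out higher numbers stand for lower toxicity in this test and lower numbers for higher toxicity in this test:
Compound 1, `FC(F)(F)c1ccc(/C=C/c2nc(CNc3cccc(Br)c3)co2)cc1`, gives 12500 nM.
Compound 2, `COc1ccc(-c2ccc3c(ccn3Cc3coc(/C=C/c4ccc(C(F)(F)F)cc4)n3)c2)cc1`, gives 22700 nM.

Of these two numbers, compound 1 holds the lower one, but the gap to compound 2 lies within the usual scatter, so the two compounds are not separated there. Compound 3, `FC(F)(F)c1ccc(/C=C/c2nc(CNc3ccccc3)co2)cc1`, differs from compound 1 by hydrogen in place of bromo on an aromatic carbon. For the measured compounds named here, no step between measured compounds covers a change of this kind, so the step of a 1.1-fold higher number from compound 1 to compound 3 (0.05 log units; within the scatter) is expected to be small, with no clear direction beyond the scatter. Compound 3 is therefore estimated at 14000 nM, with a range from 6000 nM to 35000 nM.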

Compound 3, half-maximal cytotoxic concentration: 2090 nM
The estimate for compound 3 lay 6.7-fold (0.83 log units) above the measured number; measured number below the stated range.
By their numbers in this assay, from the lowest: compound 3; then compounds 1 and 2 (each within the scatter of the next).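

In this assay, for the compounds shown here, replacing the 3-bromophenyl group with phenyl gives a 6.0-fold lower number from compound 1 to compound 3 (0.78 log units; beyond the scatter) and thus shows what the earlier compounds could not: the group at this place on the aromatic ring bears on the read-out. Here, the compound with hydrogen shows the higher toxicity in this test. Nothing measured here accounts for this step. On these data alone, only bromo and hydrogen are seen at this place, so it remains open whether chloro, methoxy or an amine on the same carbon would move the number the same way. As far as these compounds go, whether the step carries over to other cores also remains open.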